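The source may hold more compounds than are shown below. What is called first, only, known or untested is meant among the compounds shown, and "the series" means these compounds.

Compound 1, `CCCCCCNC(=O)Oc1ccc(Cl)cc1C(=O)Nc1cccc(Cl)c1`, carries a carbamate on the shared core with a chain of six carbons on its nitrogen, and in an ADME assay for metabolic stability, read by HPLC, at pH 7 (a lower number here means that the compound disappears faster, a higher number that the compound lasts longer), compound 1 gives 64 h. Compound 2, `CCCCCCCNC(=O)Oc1ccc(Cl)cc1C(=O)Nc1cccc(Cl)c1`, differs from it by methyl in place of hydrogen on a saturated chain carbon, six bonds along the chain from an amide-type nitrogen; in this assay compound 2 gives 64 h, so the step of no change at the digits printed from compound 1 to compound 2 (within the scatter) is small. Compound 3, `CCCCCCCCCNC(=O)Oc1ccc(Cl)cc1C(=O)Nc1ccc(Cl)cc1`, has a different core: how the core of compound 3 differs from the core of compound 1 is not broken down here. In this assay compound 3 gives 64 h, level with compound 1 and compound 2 at the digits shown.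

Compound 4, `CCCCCCCCCCNC(=O)Oc1ccc(Cl)cc1C(=O)Nc1ccc(Cl)cc1`, has not yet been measured. It differs from compound 3 by methyl in place of hydrogen on a saturated chain carbon, nine bonds along the chain from an amide-type nitrogen. For the measured compounds named here, this is the same kind of change as the one from compound 1 to compound 2, though not the same: there the added carbon sits six bonds along the chain from an amide-type nitrogen, here it sits nine bonds along. Because the earlier step of no change at the digits printed from compound 1 to compound 2 (within the scatter) left the half-life unchanged within the scatter, and because compound 3 already gives 64 h, the step from compound 3 to compound 4 is expected to be no change at the digits printed from compound 3 to compound 4 (within the scatter), small. On that basis compound 4 is estimated to give 64 h in this assay, with the estimate expected to lie between 32 h and 128 h.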

Compound 4, half-life: 64 h
The estimate for compound 4 equals the measured number at the digits printed, within the range that was stated.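

On the core of compound 3, the added methyl, nine bonds along the chain from an amide-type nitrogen, leaves the half-life where it was in this assay (no change at the digits printed from compound 3 to compound 4 (within the scatter)), and the same kind of change on the core of compound 1 reads the same way, so within this small set the step carries over from one core to the other: the same change on two cores in this assay, no change at the digits printed (within the scatter) from compound 1 to compound 2 and no change at the digits printed (within the scatter) from compound 3 to compound 4, 1.0-fold (0.00 log units) apart, within the scatter of two such steps. For the compounds shown here, this agreement does not show that the result would hold on any further core, since only two cores appear here, and the added carbon also sits at a different place in each step, six bonds along the chain in one and nine in the other. Neither step moves the half-life, so the pair shows only that a null result repeats, and it cannot show whether a change that does move the number would carry over in the same way.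

The compounds shown leave open how the half-life responds to a chain shorter than that of compound 1 or longer than that of compound 4. They also leave open what an amine or a carboxylic acid on the chain would do in this assay, and whether such a group would behave alike on both cores.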